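Will a methoxypyridine keep compound 2 stable?

A few compounds are considered here, and "the series" means these few. Any claim that something is new, unique, unknown or untested is made for them only; others in the source may bear on it.

- compound 1 `COc1ccc(-n2c(C)nc3c(N4CC[C@@H](NC(C)=O)C4)nc(C)nc32)cc1OC` gives > 95%
- compound 2 `CC(=O)N[C@@H]1CCN(c2cc(C)nn3c(-c4ccccc4)c(C)nc23)C1` gives > 95%
- compound 3 `CC(=O)N[C@@H]1CCN(c2cc(C)nn3c(-c4cccc(S(=O)(=O)N(C)C)c4)c(C)nc23)C1` gives > 95%

These results come from an ADME assay on microsomes from liver (Homo sapiens) for metabolic stability, read by LC-MS, with NADPH named in the record, with a stated time of 60 min, tested at 1 uM, in the absence of a further agent (on this read-out higher numbers stand for a more stable compound and lower numbers for a less stable compound), and show (the limit of > 95% in this assay, at which 3 of the 3 values shown sit). Compound 2 gives > 95%, which is a limit and not a number. Compound 4 `COc1ccc(-c2c(C)nc3c(N4CC[C@@H](NC(C)=O)C4)cc(C)nn23)cn1` keeps the shared core of compound 2 and changes one group: 6-methoxypyridin-3-yl in place of phenyl on an aromatic carbon. In words, this is 6-methoxypyridin-3-yl in place of phenyl on an aromatic carbon. The nearest measured change is a step that the two limits leave unreadable from compound 2 to compound 3, and it gives no size. Compound 1 also bears methoxy groups and gives > 95% as a limit. A small downward change is therefore expected, shown as a number at least 5 percentage points lower from compound 2 to compound 4 (that floor lies within the scatter). The estimate for compound 4 is 90% within an expected range from 72% to 100%.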

Compound 4, percent of the compound remaining: > 95%
Compound 4: a limit, no number; the forecaster's own chance of this, stated with the estimate: 50%; middle value at least 5 percentage points from the limit.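

In this assay compound 2 and compound 4 both give limits rather than numbers, so no step between them can be read: the limit of > 95% in this assay, at which 4 of the 4 values shown sit.

The compounds shown leave open how far their stability truly differs, and whether any change on the shared core would lower the percent remaining.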